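Compound 4: a dinitrophenyl swap at the limit

The source may hold more compounds than are shown below. What is called first, only, known or untested is meant among the compounds shown, and "the series" means these compounds.

Of the compounds shown here, three sharing one core have been tested in a functional assay on MCF7 cells (Homo sapiens) for antiproliferative activity, read by MTT assay, with a stated time of 48 h; a lower number here means a stronger inhibitor, a higher number a weaker inhibitor. Compound 1 `CCc1ccccc1-n1nncc1CN1C(=O)C2(C(C#N)=C(N)Oc3c(N)cc4nc5ccccc5nc4c32)c2ccccc21` gives 24600 nM in this assay. Compound 2 `CCOc1ccccc1-n1nncc1CN1C(=O)C2(C(C#N)=C(N)Oc3c(N)cc4nc5ccccc5nc4c32)c2ccccc21` reaches only the limit of this assay, recorded as > 50000 nM, which is a limit and not a number. Compound 3 `Cc1ccc(-n2nncc2CN2C(=O)C3(C(C#N)=C(N)Oc4c(N)cc5nc6ccccc6nc5c43)c3ccccc32)cc1Cl` likewise reaches only a limit, recorded as > 50000 nM. Compound 3 therefore stands at the limit of > 50000 nM in this assay, at which 2 of the 3 values shown sit.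

The change to compound 4 `N#CC1=C(N)Oc2c(N)cc3nc4ccccc4nc3c2C12C(=O)N(Cc1cnnn1-c1ccc([N+](=O)[O-])cc1[N+](=O)[O-])c1ccccc12` is 2,4-dinitrophenyl in place of 3-chloro-4-methylphenyl on an aromatic nitrogen. Going by the values given here, two measured steps bear on the same position. Going from compound 1 to compound 3, a different group on that aromatic nitrogen gave an at least 2.0-fold higher number from compound 1 to compound 3 (0.30 log units; that floor lies within the scatter). Going from compound 2 to compound 3, the change gave a step that the two limits leave unreadable from compound 2 to compound 3, because both of those compounds sit at the limit and the step cannot be read. Neither measured step shows that exchanging the group on this aromatic nitrogen brings a stronger inhibitor, and compound 3 itself is already at the limit. Compound 4 is therefore expected near 50000 nM, within a range from 15000 nM to 150000 nM, most likely again reported only as a limit. The step this estimate implies, a number no higher from compound 3 to compound 4 (the limit leaves the size open), is expected to stay within the scatter.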

Compound 4, half-maximal inhibitory concentration: 20900 nM
Compound 4: the middle estimate sits 2.4-fold (0.38 log units) above what was measured; measured number inside the range.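

In this assay, the earlier exchanges on this aromatic nitrogen showed only a higher number or a step that could not be read between two limits, whereas 2,4-dinitrophenyl gives the first readable move towards a stronger inhibitor among steps starting from those limit compounds: an at least 2.3-fold lower number from compound 3 to compound 4 (0.37 log units; beyond the scatter), and an at least 2.3-fold lower number from compound 2 to compound 4 (0.37 log units; beyond the scatter). Set against the 2-ethylphenyl group, the same group gives a 1.2-fold lower number from compound 1 to compound 4 (0.07 log units; within the scatter), so compound 1 and compound 4 stand level in this assay. The position therefore does not simply lose activity whenever its group is exchanged, since 2,4-dinitrophenyl, with more heavy atoms than the 3-chloro-4-methylphenyl it replaces and with hydrogen-bond acceptors that group lacks, still gives a readable number.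

On these data alone, how far compound 2 and compound 3 truly lie from the others stays open, as each is recorded only as a limit and not as a number: the limit of > 50000 nM in this assay, at which 2 of the 4 values shown sit. As far as these compounds go, whether both nitro groups are needed also stays open, and a phenyl ring carrying a single nitro group, an amine or a carboxylic acid would test what this position accepts.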